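The source may hold more compounds than are shown below. What is called first, only, known or untested is meant among the compounds shown, and "the series" means these compounds.

Compound 1, `CC(=O)N1CCC(C(=O)N(CCCN2CCC(CNC(=O)c3cnccn3)CC2)c2ccc(C)c(Cl)c2)CC1`, gives in an ADME assay (Homo sapiens) for cytotoxicity (on this read-out higher numbers stand for lower toxicity in this test and lower numbers for higher toxicity in this test), the value > 52400 nM, which is a limit of the assay and not a number.
Compound 2, `CC(=O)N1CCC(C(=O)N(CCCN2CCN(Cc3ccc(S(C)(=O)=O)cc3)CC2)c2ccc(C)c(Cl)c2)CC1`, gives in this assay the value > 49200 nM, which is also a limit and not a number.
Compound 3, `CC(=O)N1CCC(C(=O)N(CCCN2CCN(Cc3ccccc3)CC2)c2ccc(C)c(Cl)c2)CC1`, gives in this assay the value 101000 nM.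

Compound 1 therefore stands only at a limit, the one described by the limit of > 52400 nM in this assay, at which 1 of the 3 values shown sits. Compound 2 sits at the limit described by the limit of > 49200 nM in this assay, at which 1 of the 3 values shown sits. Only compound 3 has a true number. Among the compounds with values here, the one step with two measured ends, a step that the limit leaves unreadable from compound 2 to compound 3, starts from a limit and cannot be read in size. Compound 4, `CC(=O)N1CCC(C(=O)N(CCCN2CCC(CNc3ncccn3)CC2)c2ccc(C)c(Cl)c2)CC1`, differs from compound 1 in one place: pyrimidin-2-yl in place of (pyrazin-2-yl)carbonyl on an amine nitrogen. Within the data shown here, no measured step touches this change, and the only measured step gives no usable size, so there is nothing to point to a shift in either direction beyond the scatter. Compound 4 is therefore expected to stay at about the same level, the estimated step that the limit leaves unreadable from compound 1 to compound 4 being small. The estimate for compound 4 in this assay is 60000 nM, within 30000 nM to 150000 nM.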

Compound 4, half-maximal cytotoxic concentration: > 55100 nM
Compound 4 was reported as a limit; the forecaster's own chance of this, stated with the estimate: 60%; the middle value is on the limit's open side.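

Compound 1 and compound 4 are both reported only as limits of the assay and not as numbers, so the step between them cannot be read. The compounds shown leave open whether pyrimidin-2-yl in place of (pyrazin-2-yl)carbonyl changes the result in this assay at all.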